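The compounds below may be only part of what the source reports. "The series", "measured", "known", "first", "only" and "open" are said of these compounds alone.

Two measured members of the series share one core and differ in more than one place. Compound 1 `CCN(Cc1cc(C(F)(F)F)ccc1-c1cc(CC(=O)O)ccc1OC)C(=O)OCc1cc(F)cc(F)c1` gives 11 nM in an in vitro assay on 293T cells for displacement of a labelled ligand from prostaglandin D2 receptor 2 (Homo sapiens), read by scintillation counting, in the presence of a further agent that is not named here; a lower number here means a stronger inhibitor, a higher number a weaker inhibitor; compound 2 `COc1ccc(CC(=O)O)cc1-c1ccc(C(F)(F)F)cc1CNC(=O)OCc1ccccc1` gives 238 nM in the same assay. Compound 2 thus stands with the higher of the two numbers, and the gap to compound 1 lies beyond the usual scatter. Among the measured compounds shown here, no single-change step between measured compounds is available, so the two values alone set the frame.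

Compound 3 `COc1ccc(CC(=O)O)cc1-c1ccc(C(F)(F)F)cc1CN(C(=O)OCc1ccccc1)C1CCC1` differs from compound 2 in one place: cyclobutyl in place of hydrogen on an amide-type nitrogen. The carbamate of compound 1 also carries a substituent on its nitrogen, and compound 1 gives 11 nM, while the unsubstituted nitrogen of compound 2 goes with 238 nM; this is a comparison of two values, not a counted step. On that basis, compound 3 is expected to move toward a lower number, with the step of a 6.8-fold lower number from compound 2 to compound 3 (0.83 log units; beyond the scatter) estimated as clearly beyond the scatter. For compound 3 the estimate in this assay is 35 nM, in the range 8 nM to 150 nM.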

Compound 3, half-maximal inhibitory concentration: 19 nM
For compound 3 the middle estimate is 1.8-fold (0.27 log units) above the measured one; the measured number falls inside the stated range.
By their numbers in this assay, from the lowest: compounds 1 and 3 (each within the scatter of the next); then compound 2.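

In this assay, cyclobutyl in place of the amide hydrogen gives a 13-fold lower number from compound 2 to compound 3 (1.10 log units; beyond the scatter), a large step. Among the compounds shown here, this is the first reading with only one place changed, which the two earlier compounds, differing in more than one place, could not give: on this amide-type nitrogen, a substituent is tolerated, and the hydrogen of compound 2 is not needed for a low number. Nothing measured here accounts for the size of this step.

Going by these compounds, whether the gain depends on the four-membered ring or would come with any carbon group on this nitrogen stays open; methyl, isopropyl or cyclopentyl at the same place would separate these cases. Also open, on these data alone, is how a substituent carrying an amine or a hydroxyl group would read at this nitrogen.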